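The source may report more compounds than this note shows. Statements on the series, on what has been measured and on what is new or still open speak of the compounds shown alone.

Compound 1, `Cc1cc(C(=O)Nc2ccccc2)nn1Cc1cc(Cl)ccc1OCc1ccccc1`, gives 39.8 nM in an assay on CHO-K1 cells for displacement of a labelled ligand from prostaglandin E2 receptor EP1 subtype (Homo sapiens); on this read-out lower numbers stand for stronger inhibition and higher numbers for weaker inhibition.
Compound 2, `Cc1cc(C(=O)Nc2ccccn2)nn1Cc1cc(Cl)ccc1OCc1ccccc1`, gives 126 nM in this assay.
Compound 3, `Cc1cc(NC(=O)C2CCOCC2)nn1Cc1cc(Cl)ccc1OCc1ccccc1`, gives 63.1 nM in this assay.

Among these three numbers compound 3 sits second highest, but both of its neighbours lie within the usual scatter of it: the step of a 1.6-fold higher number from compound 1 to compound 3 (0.20 log units; within the scatter) and the step of a 2.0-fold lower number from compound 2 to compound 3 (0.30 log units; within the scatter) are both too small to count as real differences. Among the compounds with values here, only the step of a 3.2-fold higher number from compound 1 to compound 2 (0.50 log units; beyond the scatter) reaches beyond the scatter, and it concerns a change at the other end of the shared core.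

Compound 4, `CCOC(=O)Nc1cc(C)n(Cc2cc(Cl)ccc2OCc2ccccc2)n1`, is not yet measured. It differs from compound 3 in one place: ethoxy in place of oxan-4-yl on a carbonyl carbon. None of the measured steps touches the group on this carbonyl carbon, so no step shown here bears directly on the change. The two steps that end at compound 3 each stayed within the scatter, and the change to compound 4 keeps the same amide-type nitrogen and the same count of hydrogen-bond acceptors, so the expectation for this assay is a step of no size beyond the scatter, in no clear direction. The expected step is a 1.0-fold lower number from compound 3 to compound 4 (0.00 log units; within the scatter). Compound 4 is therefore estimated at about 63 nM, with a range from 25 nM to 160 nM.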

Compound 4, half-maximal inhibitory concentration: 79.4 nM
For compound 4 the middle estimate is 1.3-fold (0.10 log units) below the measured one; measured number inside the range.
By their numbers in this assay, from the lowest: compounds 1, 3, 4 and 2 (each within the scatter of the next, the first and the last beyond it).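

Replacing the oxan-4-yl ring on the carbonyl carbon with open-chain ethoxy removes the ring and lowers the heavy-atom count of the group from 6 to 3, yet this gives a 1.3-fold higher number from compound 3 to compound 4 (0.10 log units; within the scatter) in this assay, so in this pair neither the ring nor the extra atoms make a difference that can be read. The wider replacements on the aromatic carbon, with (ethoxycarbonyl)amino taking the place of an aryl-bearing carbamoyl group, also stay within the scatter: a 2.0-fold higher number from compound 1 to compound 4 (0.30 log units; within the scatter) and a 1.6-fold lower number from compound 2 to compound 4 (0.20 log units; within the scatter). Nothing measured here explains why these changes leave the number so little altered.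

With only oxan-4-yl and ethoxy shown on this carbonyl carbon, it remains open whether an amine such as piperidin-4-yl, a carboxylic acid or a longer chain such as butoxy would also stay within the scatter. Going by these compounds, it is equally open whether a smaller group such as methoxy would do so, which would show how far this position can be trimmed.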